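A few compounds are considered here, and "the series" means these few. Any claim that something is new, unique, unknown or untested is made for them only; others in the source may bear on it.

Of the compounds shown here, three of a shared core have been measured. Compound 1 `COc1ccccc1NC1=CC(=O)c2c(nc3n2[C@H]2OC[C@@H](O)[C@H]2OC3)C1=O` carries a (2-methoxyphenyl)amino group on a double-bonded ring carbon, and in a functional assay on HeLa cells (Homo sapiens) for inhibition, read by sulforhodamine B assay (a higher number here means a weaker inhibitor, a lower number a stronger inhibitor), compound 1 gives 7460 nM. Compound 3 `CCCN(CCC)C1=CC(=O)c2c(nc3n2[C@H]2OC[C@@H](O)[C@H]2OC3)C1=O` carries dipropylamino in place of (2-methoxyphenyl)amino on a double-bonded ring carbon, and in this assay compound 3 gives > 16000 nM, which is a limit of the assay and not a number. Among the measured compounds shown here, the step of an at least 2.1-fold higher number from compound 1 to compound 3 (0.33 log units; beyond the scatter) is the only measured step, and it rests on (the limit of > 16000 nM in this assay, at which 1 of the 3 values shown sits).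

Compound 2 `O=C1C=C(Nc2ccc(C(F)(F)F)cc2)C(=O)c2c1nc1n2[C@H]2OC[C@@H](O)[C@H]2OC1` carries a 4-(trifluoromethyl)phenyl group on the amine nitrogen. In this assay compound 2 gives > 8000 nM, again a limit of the assay rather than a number, as the limit of > 8000 nM in this assay, at which 1 of the 3 values shown sits, records. Compound 2 therefore stands among the weaker compounds shown, with no exact figure.

Compound 4 `O=C1C=C(Nc2ccccc2F)C(=O)c2c1nc1n2[C@H]2OC[C@@H](O)[C@H]2OC1` differs from compound 2 by 2-fluorophenyl in place of 4-(trifluoromethyl)phenyl on an amine nitrogen. For the measured compounds named here, no measured step bears on this change; the step from compound 1 to compound 3 concerns a different group. Compound 1, with its own aryl group on the amine nitrogen, reached a number, so compound 4 is expected to land near that region, with the step that the limit leaves unreadable from compound 2 to compound 4 expected to be small and uncertain. Compound 4 is estimated at 9000 nM, between 3500 nM and 25000 nM.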

Compound 4, half-maximal inhibitory concentration: 5120 nM
Beside the measured number, compound 4's estimate is 1.8-fold (0.24 log units) above it; the measured number falls inside the stated range.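

The change to 2-fluorophenyl in place of 4-(trifluoromethyl)phenyl on this amine nitrogen gives an at least 1.5-fold lower number from compound 2 to compound 4 (0.19 log units; that floor lies within the scatter), and the true size of that step cannot be read, since the value of compound 2 is a limit of the assay and not a number: the limit of > 8000 nM in this assay, at which 1 of the 4 values shown sits.

What compound 4 adds is a second exact number for an aryl group on this nitrogen: in this assay compound 1 gives 7460 nM and compound 4 gives 5120 nM. Changing the aryl group from that of compound 1 to that of compound 4 therefore leaves the number in the same region.

The compounds shown cannot separate the kind of substituent on the phenyl ring from its place, and a 4-fluorophenyl group on the same amine nitrogen would bear directly on that question. They also leave open how an unsubstituted phenyl group, or a phenyl group carrying a nitrile or a carboxylic acid, would read in this assay.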